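Replacing a Sulfonamide Group with a Butyl Ester

The source may report more compounds than this note shows. Statements on the series, on what has been measured and on what is new or still open speak of the compounds shown alone.

Of the compounds shown here, three have been tested so far in an assay on COS-7 cells for inhibition of patatin-like phospholipase domain-containing protein 2 (Mus musculus), tested at 200 uM; on this read-out lower numbers stand for less inhibition and higher numbers for more inhibition at the one concentration tested (going by the name of the read-out). Compound 1 `CCOC(=O)c1cncc(-c2ccc(OCC)cc2)c1` gives 70%, compound 2 `CCOC(=O)c1cccc(-c2ccc3c(ccn3C)c2)c1` gives 84%, and compound 3 `CCOc1ccc(-c2cccc(S(=O)(=O)N(C)C)c2)cc1` gives 63%. Compound 3 stands at the low end of this small set: its number and that of compound 1 lie within the usual scatter of each other and so cannot be told apart, whereas compound 2 lies clearly higher, beyond the scatter.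

The next compound, compound 4 `CCCCOC(=O)c1cccc(-c2ccc(OCC)cc2)c1`, differs from compound 3 in a single place (butoxycarbonyl in place of dimethylsulfamoyl on an aromatic carbon). For the measured compounds named here, no measured pair shows this exact change, so its size is uncertain. The two compounds that carry a carbonyl-bearing group of this kind, compound 1 and compound 2, both give larger numbers than compound 3, which suggests a modest step upward rather than none.

For compound 4 the expected value in this assay is 75%, within a range of 58% to 90%, and the estimated step of a number 12 percentage points higher from compound 3 to compound 4 (beyond the scatter) is upward by a little more than the scatter.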

Compound 4, a percentage reported as inhibition, at one concentration (the size of the read-out at that concentration, not a potency): 61%
Compound 4: the middle estimate sits 14 percentage points above what was measured; the range from low to high includes it.
By their numbers in this assay, from the lowest: compounds 4, 3 and 1 (each within the scatter of the next); then compound 2.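

In this assay, butoxycarbonyl in place of dimethylsulfamoyl on an aromatic carbon gives a number 2 percentage points lower from compound 3 to compound 4 (within the scatter) and so leaves the two compounds impossible to tell apart. At this position, a group holding sulfur and nitrogen and an ester group holding a carbonyl and a longer carbon chain give readings that this assay does not separate, so putting this ester here brings no readable gain. Nothing measured on these compounds offers an explanation for this result.

From the compounds shown here alone, whether any group at this place can move the number beyond the scatter stays open, for instance a carboxylic acid or an amine in place of the ester. For the compounds shown here, this change is also seen in only one pair, so its effect on any other core remains unknown.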